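The compounds below may be only part of what the source reports. "The series", "measured", "known", "first", "only" and "open" are said of these compounds alone.

Measured compounds: compound 1, `CC(=O)Oc1ccccc1C1CC(C)=NN1C(=O)CN1CCC(O)CC1`, gives 12300 nM in a functional assay on HepG2 cells (Homo sapiens) for cytotoxicity, read by MTT assay, with a stated time of 48 h; a lower number here means a stronger inhibitor, a higher number a weaker inhibitor. Compound 2, `CC(=O)Oc1ccccc1C1CC(C)=NN1C(=O)CCl`, gives 2520 nM. Compound 3, `O=C(c1ccccc1)N1N=C(c2cc3ccccc3oc2=O)CC1c1ccccc1`, gives 36600 nM.

Among these three numbers compound 3 stands highest, that is, it is the weakest inhibitor of the set: compound 1 comes nearest to it, and compound 2 lies furthest away, with both gaps beyond the scatter.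

Compound 4, `CC1CC(C)CN(CC(=O)N2N=C(c3cc4ccccc4oc3=O)CC2c2ccccc2)C1`, is not yet measured. It is made from compound 3 by one change: (3,5-dimethylpiperidin-1-yl)methyl in place of phenyl on a carbonyl carbon. Read one bond further out, the change is benzoyl to ((3,5-dimethylpiperidin-1-yl)methyl)carbonyl.

For the measured compounds named here, only one measured step touches a related change, a 4.9-fold lower number from compound 1 to compound 2 (0.69 log units; beyond the scatter). There a piperidine ring on a chain carbon next to the carbonyl was removed and the number fell by a modest amount; compound 4 goes the other way, a piperidine ring arriving on such a chain. That step belongs to a different core, so it is a loose guide at best. A small rise, or no step beyond the scatter, is therefore expected in this assay.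

For compound 4 the estimate is 50000 nM, with a likely range from 15000 nM to 160000 nM. The expected step, a 1.4-fold higher number from compound 3 to compound 4 (0.14 log units; within the scatter), is small.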

Compound 4, half-maximal inhibitory concentration: "not active" (no number reported)
Compound 4: no number reported, and the estimate cannot be compared.
By their numbers in this assay, from the lowest: compound 2; then compound 1; then compound 3.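

For the compounds shown here, compound 4 is reported as not active in this assay, with no number, so no step from compound 3 to compound 4 can be read. No other data shown here bear on this result. The compounds shown leave open how far (3,5-dimethylpiperidin-1-yl)methyl in place of phenyl moves the number on this core.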